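From 1-Methylpyrrolidin-3-yl to (Propylamino)methyl: an Expected Step

The compounds below may be only part of what the source reports. "The series", "measured", "known", "first", "only" and "open" are said of these compounds alone.

Among the measured compounds shown here, compound 1 `COc1ccccc1-c1cc(C2CCN(C)C2)ccc1Cl` gives 1000 nM in an assay on isolated protein for binding affinity to 5-hydroxytryptamine receptor 5A (Homo sapiens) (a higher number here means a weaker inhibitor, a lower number a stronger inhibitor), the highest of the two numbers measured so far. Its nearest neighbour is compound 2 `CNCc1ccc(Cl)c(-c2ccccc2OC)c1`, which in this assay gives 420 nM; the step of a 2.4-fold lower number from compound 1 to compound 2 (0.38 log units; beyond the scatter) is modest but beyond the scatter. Compound 3 `CCCNCc1ccc(Cl)c(-c2ccccc2OC)c1` has not yet been measured in this assay. Compared with compound 1 it carries (propylamino)methyl in place of 1-methylpyrrolidin-3-yl on an aromatic carbon. For the measured compounds named here, the only measured step that bears on this change is the one between compound 1 and compound 2, where the same ring left and (methylamino)methyl entered. Because compound 2 gives 420 nM and (propylamino)methyl resembles (methylamino)methyl, compound 3 is expected to show a step of similar size and direction, a 2.2-fold lower number from compound 1 to compound 3 (0.35 log units; beyond the scatter), toward a lower number. Compound 3 is therefore estimated at 450 nM, with a range from 150 nM to 1300 nM.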

Compound 3, inhibition constant: 120 nM
Estimate against measurement, compound 3: 3.8-fold (0.57 log units) above, outside the stated range (below it).
By their numbers in this assay, from the lowest: compound 3; then compound 2; then compound 1.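

In this assay the position on an aromatic carbon, para to the chloro group, tolerates more than the first replacement of the 1-methylpyrrolidin-3-yl ring suggested: (propylamino)methyl gives an 8.3-fold lower number from compound 1 to compound 3 (0.92 log units; beyond the scatter), a larger step than that ring's replacement by (methylamino)methyl had shown. Among the compounds shown here, the new comparison also shows that the substituent on the amine nitrogen matters here, since ethyl in place of hydrogen on the saturated chain carbon bound to that nitrogen gives a 3.5-fold lower number from compound 2 to compound 3 (0.54 log units; beyond the scatter), a change that no earlier pair could show. No measurement shown here accounts for either step.

As far as these compounds go, two compounds with an open chain cannot establish a trend with chain length, so it remains open whether a butyl or longer chain on the nitrogen would lower the number further. Also open, from the compounds shown here alone, is how a branched isopropyl group or a tertiary dimethylamine would compare at this position.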